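From compound 3 to compound 4: same atoms, rejoined

The compounds below may be only part of what the source reports. "The series", "measured", "known", "first", "only" and "open" are said of these compounds alone.

Measured in a functional assay on cells (Mast cell, Rattus norvegicus, strain Wistar) for activation, read by fluorescence, with a stated time of 15 min; on this read-out lower numbers stand for an effect already at smaller amounts and higher numbers for an effect only at larger amounts of compound:
compound 1 `CCCCCCCCCCCCCCCCCC(=O)CCCCOP(=O)(O)OC[C@H](N)C(=O)O`: 5000 nM
compound 2 `CCCCCCCCCCCCCCCCCC(=O)OC[C@@H](O)COP(=O)(O)O[C@@H](C)[C@H](N)C(=O)O`: 2000 nM
compound 3 `CCCCCCCCCCCCCCCCCC(=O)OC[C@@H](O)COP(=O)(O)O[C@@H]1CCN[C@H]1C(=O)O`: > 10000 nM (a limit of the assay, not a number)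

Compound 3 stands at the limit of > 10000 nM in this assay, at which 1 of the 3 values shown sits, so it has a limit and no exact value. Compound 4 `CCCCCCCCCCCCCCCCCC(=O)OC[C@@H](O)COP(=O)(O)O[C@H]1CN[C@@H](C(=O)O)C1` has the same atoms as compound 3 , joined differently: a group of 8 heavy atoms (5 carbon, 1 nitrogen, 2 oxygen; one five-membered non-aromatic ring with 1 hetero atom) in place of a group of 8 heavy atoms (5 carbon, 1 nitrogen, 2 oxygen; one five-membered non-aromatic ring with 1 hetero atom), on an oxygen. Among the compounds with values here, one measured step bears on this: an at least 5.0-fold higher number from compound 2 to compound 3 (0.69 log units; beyond the scatter), where the five-membered ring came in. Compound 4 also carries such a ring, so no step beyond the scatter is expected in this assay, though this single step is thin support. The expected change is a number no higher from compound 3 to compound 4 (the limit leaves the size open). Compound 4 is estimated at 10000 nM, within a range of 3000 nM to 30000 nM.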

Compound 4, half-maximal effective concentration: > 10000 nM
Compound 4: a limit, no number; the forecaster's own chance of this, stated with the estimate: 60%; the middle value sits exactly at the limit.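

In this assay, the second ring arrangement on the oxygen bonded to phosphorus also gives an at least 5.0-fold higher number from compound 2 to compound 4 (0.69 log units; beyond the scatter), so the loss seen with the first ring arrangement is not confined to one way of joining these atoms. Compound 4 carries a limit, as does compound 3, and the step between them cannot be read. Both ring compounds now rest at the same limit: the limit of > 10000 nM in this assay, at which 2 of the 4 values shown sit.

As far as these compounds go, how far beyond that limit either compound lies stays open. So does whether a six-membered ring carrying the same amine and carboxylic acid would behave like these five-membered rings.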